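A few compounds are considered here, and "the series" means these few. Any claim that something is new, unique, unknown or untested is made for them only; others in the source may bear on it.

Of the compounds shown here, two that share the same core have been tested in a functional assay on MCF7 cells (Homo sapiens) for inhibition, read by MTT assay, with a stated time of 48 h; a lower number here means a stronger inhibitor, a higher number a weaker inhibitor. Compound 1 `O=C(C=CNc1cc(-c2ccccc2)nn1-c1ccccc1)c1ccccc1` carries a benzoyl group linked to the core through a short unsaturated chain, while compound 2 `Cc1ccc(-c2ccnc3c2c(-c2ccccc2)nn3-c2ccccc2)cc1` has a ring fused onto the core and a methyl-bearing phenyl on it. In this assay compound 1 gives 9650 nM, the higher of the two numbers, and compound 2 gives 5590 nM; the two values lie within the usual scatter of repeated measurements, so they give no real order between these compounds.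

Compound 3 `Cc1ccc(C(=O)C=CNc2cc(-c3ccccc3)nn2-c2ccccc2)cc1` differs from compound 1 in a single place: methyl in place of hydrogen on an aromatic carbon. Put another way, the benzoyl becomes a (4-methylphenyl)carbonyl.

For the measured compounds named here, no pair among the measured compounds differs in just one place, so there is no measured step to lean on. For so small an addition, the expected step of a 1.1-fold lower number from compound 1 to compound 3 (0.06 log units; within the scatter) is slight, not expected to exceed the scatter in either direction. Compound 3 is therefore estimated at 8500 nM, with a range from 3500 nM to 20000 nM.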

Compound 3, half-maximal inhibitory concentration: 30200 nM
Compound 3: middle estimate off by 3.6-fold (0.55 log units), on the low side; measured number above the stated range.
By their numbers in this assay, from the lowest: compounds 2 and 1 (each within the scatter of the next); then compound 3.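

The change gives a 3.1-fold higher number from compound 1 to compound 3 (0.50 log units; beyond the scatter) in this assay, and that step lies beyond the scatter, in the direction of a weaker inhibitor. For the compounds shown here, it is the first measured evidence about this position: on this aromatic carbon, para to a large group, replacing a hydrogen with a methyl, which adds just one carbon and no hydrogen-bond donors or acceptors, is enough to produce a real change in the number. Nothing available here explains why the number rises.

A single substituent cannot show whether this result is specific to methyl or extends to other groups on the benzoyl ring. Going by these compounds, it remains open whether a chlorine, a methoxy group, a hydroxyl or an amine on this same aromatic carbon would also raise the number, leave it within the scatter or lower it, and whether a longer chain such as ethyl would move it further than methyl does.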